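Pyridyl isomers on the aryl ether side chain

The source may hold more compounds than are shown below. What is called first, only, known or untested is meant among the compounds shown, and "the series" means these compounds.

In a functional assay on cells (Erythrocyte, Homo sapiens), with a stated time of 2 h, tested at 0.5 mM (a higher number here means a stronger effect of the compound at the concentration tested, a lower number a weaker effect), compound 2 `COc1ccc(OCc2cccnc2)c(C=O)c1` gives 14.9% and compound 1 `COc1ccc(OCc2ccccn2)c(C=O)c1` gives 24.3%; the step of a number 9.4 percentage points lower from compound 1 to compound 2 (within the scatter) is within the scatter, so the two compounds sit together and neither can be set above the other. Compound 3 `COc1ccc(OCc2ccncc2)c(C=O)c1` carries the change (pyridin-4-yl in place of pyridin-3-yl on a saturated chain carbon bound to an oxygen on an aromatic ring). Within the data shown here, the only step that bears on it, a number 9.4 percentage points lower from compound 1 to compound 2 (within the scatter), was the same kind of exchange and stayed within the scatter. For compound 3 a step of a number 2.1 percentage points higher from compound 2 to compound 3 (within the scatter) is therefore expected, with no direction beyond the scatter. Compound 3 is estimated at 17%, in a range from 5% to 30%.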

Compound 3, a percentage reported as inhibition, at one concentration (the size of the read-out at that concentration, not a potency): 21.7%
Beside the measured number, compound 3's estimate is 4.7 percentage points below it, within the range that was stated.
By their numbers in this assay, from the lowest: compounds 2, 3 and 1 (each within the scatter of the next).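

Among these compounds, with pyridin-4-yl the three pyridyl isomers are all in hand, and in this assay the steps of a number 6.8 percentage points higher from compound 2 to compound 3 (within the scatter) and a number 2.6 percentage points lower from compound 1 to compound 3 (within the scatter) leave no pair separated. On a saturated chain carbon bound to an oxygen on an aromatic ring, pyridin-2-yl, pyridin-3-yl and pyridin-4-yl therefore cannot be told apart by this read-out. Nothing available explains why the three isomers read alike.

Open, from the compounds shown here alone, is whether a non-pyridyl group at this place, such as a phenyl ring, a carboxylic acid or a longer chain carrying an amine, would move the read-out beyond the scatter.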